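A few compounds are considered here, and "the series" means these few. Any claim that something is new, unique, unknown or untested is made for them only; others in the source may bear on it.

Measured compounds in this series:

- compound 1 `N[C@H]1CC[C@H](Nc2c(C(=O)NCc3ccc(F)cc3)nc(N3CCCCC3)c3cccnc23)CC1`: 5000 nM
- compound 3 `N[C@H]1CC[C@H](Nc2c(C(=O)NCc3ccccc3)nc(Br)c3cccnc23)CC1`: 7000 nM
- compound 2 `CS(=O)(=O)NCCCN(c1nc(C(=O)NCc2ccc(F)cc2)c(O)c2ncccc12)S(C)(=O)=O`: > 20000 nM (a limit of the assay, not a number)

In a functional assay on MDA-MB-435 cells (Homo sapiens) for cytotoxicity, read by MTT assay, with a stated time of 72 h (a higher number here means a weaker inhibitor, a lower number a stronger inhibitor), compound 1 gives 5000 nM, the lowest of the two numbers recorded. Compound 3 gives 7000 nM in this assay; that value sits within the usual scatter of compound 1, so the two cannot be ranked against each other. Compound 2 reaches only the limit > 20000 nM in this assay, and nothing more than that can be said of it; this is the case of the limit of > 20000 nM in this assay, at which 1 of the 3 values shown sits.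

Compound 4 `N[C@H]1CC[C@H](Nc2c(C(=O)NCc3ccc(F)cc3)nc(N3CCCCS3(=O)=O)c3cccnc23)CC1` is the next compound, not yet measured in this assay. Relative to compound 1 the change is a group of 8 heavy atoms (4 carbon, 1 nitrogen, 2 oxygen, 1 sulfur; one six-membered non-aromatic ring with 2 hetero atoms) in place of a group of 6 heavy atoms (5 carbon, 1 nitrogen; one six-membered non-aromatic ring with 1 hetero atom), on an aromatic carbon. For the measured compounds named here, no pair of measured compounds differing in one place is available, so there is no measured step to lean on for the size of this change.

The expectation is a modest step from compound 1 toward a somewhat weaker number, a 1.6-fold higher number from compound 1 to compound 4 (0.20 log units; within the scatter), but one that may well stay within the scatter. Compound 4 is therefore estimated at 8000 nM in this assay, with a range from 3000 nM to 20000 nM.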

Compound 4, half-maximal inhibitory concentration: 5000 nM
The estimate for compound 4 lay 1.6-fold (0.20 log units) above the measured number; the range from low to high includes it.
By their numbers in this assay, from the lowest: compounds 1, 4 and 3 (each within the scatter of the next). At a limit, above all of these: compound 2.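

In this assay, placing the six-membered ring with its sulfur and two oxygens instead of piperidin-1-yl, on the aromatic carbon next to the ring nitrogen, gives no change at the digits printed from compound 1 to compound 4 (within the scatter). For the compounds shown here, this is the first pair differing in one place, and it shows that this position accepts the larger group of 8 heavy atoms, with its second ring hetero atom and 2 hydrogen-bond acceptors, without a change that can be told from the scatter while the (4-fluorobenzyl)carbamoyl and (4-aminocyclohexyl)amino groups stay fixed. Nothing measured in the series bears on why the read-out holds here.

On these data alone, whether a morpholine ring, a piperazine ring with a free amine, or an open dimethylamino group on the same carbon would shift the number remains open. Compound 3 differs from compound 1 at this carbon and also on the benzyl group, and compound 2 differs in several places, so no further steps can be read from them.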